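Methylsulfonyl in place of sulfamoyl on the methoxy analogue

A few compounds are considered here, and "the series" means these few. Any claim that something is new, unique, unknown or untested is made for them only; others in the source may bear on it.

Among the compounds with values here, compound 3 `COc1ccc2nc(Nc3ccnc(Nc4ccc(S(N)(=O)=O)cc4)n3)sc2c1` gives 1730 nM in a functional assay on HeLa cells (Homo sapiens) for antiproliferative activity, read by MTT assay, with a stated time of 48 h (on this read-out lower numbers stand for stronger inhibition and higher numbers for weaker inhibition), the second highest of the three numbers measured so far. Compound 1 `CS(=O)(=O)c1ccc(Nc2nccc(Nc3nc4ccc(F)cc4s3)n2)cc1` gives 560 nM in this assay, and compound 2 `Cc1ccc2nc(Nc3ccnc(Nc4ccc(S(C)(=O)=O)cc4)n3)sc2c1` gives 2300 nM; the values of compound 2 and compound 3 lie within the scatter of each other, while the number of compound 3 is beyond the scatter away from that of compound 1. Within the data shown here, the only single-point step recorded is a 4.1-fold higher number from compound 1 to compound 2 (0.61 log units; beyond the scatter), which concerns the other end of the molecule.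

Compound 4 `COc1ccc2nc(Nc3ccnc(Nc4ccc(S(C)(=O)=O)cc4)n3)sc2c1` differs from compound 3 by methyl in place of amino on a sulfonyl sulfur. Among the measured compounds shown here, no measured step covers this change; compound 1 and compound 2 already carry the methylsulfonyl group, and compound 3 the sulfamoyl, but they also differ elsewhere, so nothing isolates the exchange. The expectation is therefore no step beyond the scatter, a 1.2-fold lower number from compound 3 to compound 4 (0.06 log units; within the scatter). Compound 4 is estimated at 1500 nM, with a range from 600 nM to 4000 nM.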

Compound 4, half-maximal inhibitory concentration: 4130 nM
Beside the measured number, compound 4's estimate is 2.8-fold (0.44 log units) below it, outside the stated range (above it).
By their numbers in this assay, from the lowest: compound 1; then compounds 3, 2 and 4 (each within the scatter of the next, the first and the last beyond it).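

On the methoxy analogue, the sulfonyl sulfur is sensitive to its substituent: methyl in place of amino gives a 2.4-fold higher number from compound 3 to compound 4 (0.38 log units; beyond the scatter) in this assay, so sulfamoyl and methylsulfonyl are not interchangeable on this core. With methylsulfonyl held constant, methoxy in place of methyl gives a 1.8-fold higher number from compound 2 to compound 4 (0.25 log units; within the scatter) and does not separate the two groups, whereas methoxy in place of fluoro gives a 7.4-fold higher number from compound 1 to compound 4 (0.87 log units; beyond the scatter) and leaves the fluoro compound clearly apart. No measurement shown accounts for the step on the sulfonyl sulfur.

On these data alone, whether sulfamoyl in place of methylsulfonyl would produce a similar step on the fluoro compound remains open. Also open, as far as these compounds go, is how a dimethylamino group or an ethyl chain on the sulfonyl sulfur would compare with amino and methyl.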